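Trimethoxy Analogue of Compound 3 in the Inhibition Assay

The source may hold more compounds than are shown below. What is called first, only, known or untested is meant among the compounds shown, and "the series" means these compounds.

Measured so far:
compound 1 `COc1ccc2[nH]cc(C(=O)/C(C#N)=C/C=C(\Cl)c3ccc(OC)c(OC)c3)c2c1` gives 58.2%
compound 2 `COc1ccc(/C(Cl)=C/C=C(\C#N)C(=O)c2c[nH]c3ccc(OC)cc23)cc1` gives 60.7%
compound 3 `COc1ccc(/C(Cl)=C/C=C(\C#N)C(=O)c2c(C)[nH]c3ccccc23)cc1OC` gives 66.4%

Of the compounds shown here, three have been tested in a functional assay for inhibition, with a stated time of 5 min, tested at 1 mM; on this read-out lower numbers stand for less inhibition and higher numbers for more inhibition at the one concentration tested (going by the name of the read-out). Compound 1 and compound 2 share one core, and the difference between them is methoxy in place of hydrogen on an aromatic carbon. The step this change made is a number 2.5 percentage points lower from compound 2 to compound 1 (within the scatter). Compound 3 carries a different core; the difference between the two cores is not broken down here. Compound 3 stands closest to compound 2 and furthest from compound 1, but both gaps lie within the scatter, so no order among the three is claimed.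

Compound 4 `COc1cc(/C(Cl)=C/C=C(\C#N)C(=O)c2c(C)[nH]c3ccccc23)cc(OC)c1OC` is not yet measured. It differs from compound 3 by methoxy in place of hydrogen on an aromatic carbon. Within the data shown here, this is the same kind of change as the one from compound 2 to compound 1, though the place is not identical: in compound 4 the entering group is also meta to a methoxy group. Because the earlier step of a number 2.5 percentage points lower from compound 2 to compound 1 (within the scatter) stayed within the scatter, the step from compound 3 to compound 4 is expected to be about a number 2.4 percentage points lower from compound 3 to compound 4 (within the scatter) in this assay. Compound 4 is therefore estimated at 64%, between 54% and 74%.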

Compound 4, a percentage reported as inhibition, at one concentration (the size of the read-out at that concentration, not a potency): 58.2%
Compound 4: the middle estimate sits 5.8 percentage points above what was measured; measured number inside the range.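

Methoxy in place of hydrogen on an aromatic carbon gave a number 8.2 percentage points lower from compound 3 to compound 4 (within the scatter) in this assay. Set beside the earlier step, the change shows no difference between the two cores that can be told apart: the same change on two cores in this assay, a number 2.5 percentage points lower (within the scatter) from compound 2 to compound 1 and a number 8.2 percentage points lower (within the scatter) from compound 3 to compound 4, 5.7 percentage points apart, within the scatter of two such steps. Among these compounds, this shows only that the two steps agree within the scatter; it does not show that the change has a real effect on either core, or that it would have the same size on a further core, and the two places are not identical, as the entering group in compound 4 is ortho to a methoxy group and also meta to a methoxy group.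

The compounds shown leave open what an amine, a carboxylic acid or a longer chain such as butoxy would do on this six-membered aromatic ring of carbon only, since methoxy is the only group entering there. Going by these compounds, all four values also come from one concentration, and how the compounds would compare in potency remains open.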